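The compounds below may be only part of what the source reports. "The series", "measured", "known", "first", "only" and "open" are said of these compounds alone.

Of the compounds shown here, three built on a shared core have been tested in an assay on membranes from brain (strain Sprague-Dawley) for displacement of a labelled ligand from metabotropic glutamate receptor 5 (Rattus norvegicus), read by scintillation counting, with a stated time of 60 min; a lower number here means a stronger inhibitor, a higher number a weaker inhibitor. Compound 1 `N#Cc1cccc(C#Cc2cccc(C(N)=O)c2)n1` carries an amide on one ring and a nitrile on the other; in this assay compound 1 gives > 10000 nM, which is a limit of the assay and not a number (the limit of > 10000 nM in this assay, at which 1 of the 3 values shown sits). Compound 2 `COc1cc(C#N)cc(C#Cc2cccc(C)n2)c1` carries a methoxy group and a nitrile on its all-carbon ring together with a methyl on the other ring; in this assay compound 2 gives 1.29 nM. Compound 3 `CCc1cccc(C#Cc2cccc(C#N)c2)n1` has the nitrile alone on the all-carbon ring and an ethyl on the other ring; in this assay compound 3 gives 3.4 nM. Of the two numbers, compound 2 stands lowest, and its gap to compound 3 lies beyond the usual scatter.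

Compound 4 `Cc1cccc(C#Cc2cc(F)cc(C#N)c2)n1` has not yet been measured. It differs from compound 2 by fluoro in place of methoxy on an aromatic carbon. Among the compounds with values here, no measured pair shows this exact swap, so the step can only be judged from compounds 2 and 3, which both sit at low values with or without the methoxy. The step from compound 2 to compound 4 is therefore expected to be small, a 1.9-fold higher number from compound 2 to compound 4 (0.29 log units; within the scatter), toward a slightly higher number or none beyond the scatter. Compound 4 is estimated at 2.5 nM, with a likely range from 0.8 nM to 8 nM.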

Compound 4, inhibition constant: 0.67 nM
The estimate for compound 4 lay 3.7-fold (0.57 log units) above the measured number; measured number below the stated range.
By their numbers in this assay, from the lowest: compounds 4 and 2 (each within the scatter of the next); then compound 3. At a limit, above all of these: compound 1.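

In this assay, the place meta to a cyano group on the all-carbon ring takes fluoro in place of methoxy with a 1.9-fold lower number from compound 2 to compound 4 (0.28 log units; within the scatter), so the two groups cannot be told apart by this measurement. Methoxy counts as a hydrogen-bond acceptor and fluoro does not, and fluoro is also the smaller group by heavy atoms, yet compound 2 and compound 4 remain together at low values; in this pair, neither the acceptor nor the extra heavy atom is needed for a low number. No measurement shown here explains why these two groups give such similar numbers.

The compounds shown leave open how much this place will accept: only methoxy and fluoro stand there alongside the nitrile, so what a chloro group, an amine or a longer chain such as propoxy would give remains unknown. Going by these compounds, it is also open whether the same swap would read alike with ethyl instead of methyl on the other ring, since compound 3 carries that ethyl but has neither methoxy nor fluoro.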